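The source may report more compounds than this note shows. Statements on the series, on what has been measured and on what is new or still open speak of the compounds shown alone.

Compound 1 `CNc1nc(Nc2cnn(CCCCCCC(=O)NO)c2)ncc1Cl` serves as the reference point of this small set. In a functional assay on MOLT-4 cells (Homo sapiens) for antiproliferative activity, read by MTT assay, with a stated time of 48 h (on this read-out lower numbers stand for stronger inhibition and higher numbers for weaker inhibition), compound 1 gives 110 nM, the lowest of the three numbers recorded, although neither of its companions is separated from it by more than the scatter. Compound 2 `O=C(CCCCCCn1cc(Nc2ncc(Cl)c(Nc3ccc(F)cc3)n2)cn1)NO` gives 220 nM in this assay, and compound 3 `O=C(CCCCCCn1cc(Nc2ncc(Cl)c(Nc3ccc(Cl)cc3)n2)cn1)NO` gives 120 nM. The step of a 2.0-fold higher number from compound 1 to compound 2 (0.30 log units; within the scatter) and the step of a 1.1-fold higher number from compound 1 to compound 3 (0.04 log units; within the scatter) each replace the methyl on a nitrogen on an aromatic ring with a substituted phenyl, and neither moves the number beyond the scatter; the step of a 1.8-fold lower number from compound 2 to compound 3 (0.26 log units; within the scatter) likewise stays inside it.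

Compound 4 `O=C(CCCCCCn1cc(Nc2ncc(Cl)c(Nc3ccccc3)n2)cn1)NO` has not yet been measured. It differs from compound 1 in one place: phenyl in place of methyl on a nitrogen on an aromatic ring. Within the data shown here, the steps that bear on this change are the two in which a 4-fluorophenyl or a 4-chlorophenyl took the place of the same methyl, and both left the number within the scatter. An unsubstituted phenyl at the same position is therefore expected to behave in the same way, giving a step of a 1.4-fold higher number from compound 1 to compound 4 (0.13 log units; within the scatter) that does not reach beyond the scatter. On this basis compound 4 is expected to give about 150 nM in this assay, with a likely range from 70 nM to 330 nM.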

Compound 4, half-maximal inhibitory concentration: 160 nM
Beside the measured number, compound 4's estimate is 1.1-fold (0.03 log units) below it; low and high end bracket the measured number.
By their numbers in this assay, from the lowest: compounds 1, 3, 4 and 2 (each within the scatter of the next).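

With the unsubstituted phenyl, the change from methylamino to anilino can be read without a halogen on the new ring: in this assay, a 1.5-fold higher number from compound 1 to compound 4 (0.16 log units; within the scatter) shows that this nitrogen on an aromatic ring also accepts plain phenyl in place of methyl without a change beyond the scatter. Removing the halogen from the phenyl makes no difference beyond the scatter either, whether hydrogen replaces chloro, a 1.3-fold higher number from compound 3 to compound 4 (0.12 log units; within the scatter), or hydrogen replaces fluoro, a 1.4-fold lower number from compound 2 to compound 4 (0.14 log units; within the scatter). Across these four compounds, methyl, phenyl, 4-fluorophenyl and 4-chlorophenyl on this nitrogen therefore all lie within the scatter of one another, and the halogens seen here are not needed to retain the number.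

The compounds shown leave open whether a benzyl group on this nitrogen, or an amine or a carboxylic acid on the phenyl ring, would stay within the scatter as well. No measurement offered here explains why this position accepts the four groups seen so far.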